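The compounds below may be only part of what the source reports. "The series", "measured", "known", "first", "only" and "open" are said of these compounds alone.

Working notes on the series. Compound 2 `CC(C)=CCC1Cc2c(OC(=O)Nc3ccc(F)cc3)cc(=O)n(CCCO)c2CC1(C)C` stands highest of the two numbers measured in a functional assay on PANC-1 cells (Homo sapiens) for inhibition, read by MTT assay, with a stated time of 24 h, tested at 10 uM; a lower number here means less inhibition, a higher number more inhibition at the concentration tested (going by the name of the read-out): compound 2 gives 71.2%, whereas compound 1 `CC(C)=CCC1Cc2c(OCc3ccccc3)cc(=O)n(CCCO)c2CC1(C)C` gives -0.3%. Going by the values given here, the single measured step, a number 71.5 percentage points higher from compound 1 to compound 2 (beyond the scatter), is large and lies beyond the scatter. Compound 3 `CC(C)=CCC1Cc2c(OC(=O)Nc3cccc(F)c3)cc(=O)n(CCCO)c2CC1(C)C` differs from compound 2 as follows: 3-fluorophenyl in place of 4-fluorophenyl on an amide-type nitrogen. Among the compounds with values here, no measured step bears directly on this change; the only step available exchanges the whole group on the ring oxygen, and compound 3 keeps the carbamoyl of compound 2, so the present change is much smaller than anything measured. The step of a number 6.2 percentage points lower from compound 2 to compound 3 (within the scatter) is therefore expected to be small and without a clear direction beyond the scatter. In this assay compound 3 is estimated at 65%, with a range from 45% to 85%.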

Compound 3, a percentage reported as inhibition, at one concentration (the size of the read-out at that concentration, not a potency): 66.1%
Estimate against measurement, compound 3: 1.1 percentage points below; the measured number falls inside the stated range.
By their numbers in this assay, from the lowest: compound 1; then compounds 3 and 2 (each within the scatter of the next).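

In this assay, 3-fluorophenyl in place of 4-fluorophenyl on the amide-type nitrogen gives a number 5.1 percentage points lower from compound 2 to compound 3 (within the scatter) and so the read-out at this position does not depend on 4-fluorophenyl alone. The large gain over benzyl on the ring oxygen also recurs with a second carbamoyl, as a number 66.4 percentage points higher from compound 1 to compound 3 (beyond the scatter) shows for (3-fluorophenyl)carbamoyl, so that gain is not confined to compound 2. Nothing available explains either step.

The compounds shown leave open whether fluorine is needed at all, which an unsubstituted phenyl or a 4-methoxyphenyl on the amide-type nitrogen would address. They also leave open whether an aromatic ring is required there, as a cyclohexyl or a short alkyl chain in its place would show.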